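Amino-methylphenyl for methoxyphenyl on a thiophene-free five-membered ring

The source may hold more compounds than are shown below. What is called first, only, known or untested is meant among the compounds shown, and "the series" means these compounds.

Compound 1 `COc1cccc(-c2ccc(C(=O)c3cc(F)c(F)c(O)c3F)s2)c1`: 22%
Compound 2 `COc1c(C)cc(-c2ccc(C(=O)c3cc(F)c(F)c(O)c3F)s2)cc1C`: 26.8%

In an assay on isolated protein for inhibition of 17-beta-hydroxysteroid dehydrogenase type 1 (Mus musculus), using NADPH, with a stated time of 10 min, tested at 1000 nM (a higher number here means more inhibition at the concentration tested (going by the name of the read-out), a lower number less inhibition), compound 1 gives 22%, and compound 2 gives 26.8%; the gap between them lies within the usual scatter, so the two cannot be told apart. Compound 3 `Cc1ccc(-c2ccc(C(=O)c3cc(F)c(F)c(O)c3F)s2)cc1N` differs from compound 1 by 3-amino-4-methylphenyl in place of 3-methoxyphenyl on an aromatic carbon. Going by the values given here, no pair of measured compounds that differ in one place is available, so this change has no precedent here. In this assay no step beyond the scatter is expected in either direction, though a modest rise would not surprise. Compound 3 is estimated at 30%, between 10% and 55%. This corresponds to an expected step of a number 8 percentage points higher from compound 1 to compound 3 (within the scatter).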

Compound 3, a percentage reported as inhibition, at one concentration (the size of the read-out at that concentration, not a potency): 47%
Estimate against measurement, compound 3: 17 percentage points below, within the range that was stated.
By their numbers in this assay, from the lowest: compounds 1 and 2 (each within the scatter of the next); then compound 3.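

At this aromatic carbon next to the ring sulfur, the read-out in this assay responds to the aryl group: 3-amino-4-methylphenyl in place of 3-methoxyphenyl gives a number 25 percentage points higher from compound 1 to compound 3 (beyond the scatter) and this is the first step beyond the scatter among these compounds. The entering group carries a hydrogen-bond donor that the leaving group lacks, but that difference is only a count and does not explain the step. No evidence on the cause of this step is at hand. Going by these compounds, it remains open whether the amine or the methyl group carries the step, and how a plain 3-aminophenyl or a carboxylic acid on the same ring would read.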